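Carbamate for Ether on the Shared Core

This account rests on a few compounds, and the source may have more. Where it says the series, first, only, none or still open, it means among the compounds named here.

Compound 1 `COCCOCC1=CS(=O)(=O)c2ccccc2C1=O` is tested in a functional assay on the whole organism for inhibition, with Mus musculus as the target, at a dose of 10 mg/kg (a higher number here means more inhibition at the dose given (going by the name of the read-out), a lower number less inhibition), where compound 1 gives 98.2%. Its neighbours share the core: compound 2 `O=C1C(CI)=CS(=O)(=O)c2ccccc21` gives 98% in this assay and compound 3 `O=C1C(CO)=CS(=O)(=O)c2ccccc21` gives 99.3%. Compound 1 stands second highest of the three numbers, yet every step among them lies within the scatter: a number 0.2 percentage points lower from compound 1 to compound 2 (within the scatter) and a number 1.1 percentage points higher from compound 1 to compound 3 (within the scatter). Compound 4 `CCNC(=O)OCC1=CS(=O)(=O)c2ccccc2C1=O` arises from compound 1 through (ethylcarbamoyl in place of 2-methoxyethyl on an oxygen on a saturated carbon). The two measured steps at this same place, from compound 1 to compound 2 and to compound 3, are both within the scatter, so no step beyond the scatter is expected in this assay. Compound 4 is therefore estimated at 97% in this assay, between 88% and 100%, an expected step of a number 1.2 percentage points lower from compound 1 to compound 4 (within the scatter).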

Compound 4, a percentage reported as inhibition, in the whole organism at one dose (the size of the read-out at that dose, not a potency): 99.3%
The estimate for compound 4 lay 2.3 percentage points below the measured number, within the range that was stated.
By their numbers in this assay, from the lowest: compounds 2, 1, 3 and 4 (each within the scatter of the next).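

With ethylcarbamoyl on the oxygen on a saturated carbon, this assay gives a number 1.1 percentage points higher from compound 1 to compound 4 (within the scatter) and no change at the digits printed from compound 3 to compound 4 (within the scatter) and also a number 1.3 percentage points higher from compound 2 to compound 4 (within the scatter) as the third step. The position therefore now holds a group with a hydrogen-bond donor and a double bond outside aromatic rings, and all four compounds still lie within the scatter of one another. As far as these compounds go, a single dose leaves these compounds unseparated, and it remains open whether an amine or a carboxylic acid at this place would give a step beyond the scatter. Nothing shown here bears on the reason for this result.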